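Methyl to tert-Butyl: Expected Cytotoxicity of Compound 4

The source may hold more compounds than are shown below. What is called first, only, known or untested is meant among the compounds shown, and "the series" means these compounds.

Three compounds sharing one core were tested in an ADME assay on HEL cells (Homo sapiens) for cytotoxicity, with a stated time of 3 days; on this read-out higher numbers stand for lower toxicity in this test and lower numbers for higher toxicity in this test. Compound 1 `CCC1(Cc2ccccc2)OS(=O)(=O)C=C1OCc1ccc(Cl)c(Cl)c1` carries a 3,4-dichlorophenyl on a saturated chain carbon bound to an oxygen on an unsaturated carbon. In this assay compound 1 reaches only a limit of the test, >= 20000 nM. Compound 2 `CCC1(Cc2ccccc2)OS(=O)(=O)C=C1OCc1ccccc1` has phenyl in that place. In this assay compound 2 likewise gives only a limit, >= 50000 nM. Compound 3 `CCC1(Cc2ccccc2)OS(=O)(=O)C=C1OCc1ccc(C)cc1` has 4-methylphenyl there. In this assay compound 3 also stops at a limit, >= 16000 nM.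

All three results are limits (the limit of >= 16000 nM in this assay, at which 1 of the 3 values shown sits, (the limit of >= 20000 nM in this assay, at which 1 of the 3 values shown sits), (the limit of >= 50000 nM in this assay, at which 1 of the 3 values shown sits)), so the steps a step that the two limits leave unreadable from compound 1 to compound 2, a step that the two limits leave unreadable from compound 1 to compound 3 and a step that the two limits leave unreadable from compound 2 to compound 3 cannot be sized. Compound 3 thus stands among three limits, with no ordering readable between any of them.

Compound 4 `CCC1(Cc2ccccc2)OS(=O)(=O)C=C1OCc1ccc(C(C)(C)C)cc1` differs from compound 3 by tert-butyl in place of methyl on an aromatic carbon. Going by the values given here, no measured step bears directly on this change, and the three unreadable steps give no direction, so no step beyond the scatter is expected. Compound 4 is therefore expected to give about 20000 nM in this assay, with a range from 8000 nM to 60000 nM, most likely again reported only as a limit. The expected step is a step that the limit leaves unreadable from compound 3 to compound 4.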

Compound 4, minimum cytotoxic concentration: >= 400000 nM
Compound 4 gave a limit, no number (the forecaster's own chance of this, stated with the estimate: 80%); middle value at least 20-fold (1.30 log units) away from the limit.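

In this assay compound 4 also stops at a limit, so its comparisons with compound 2 and compound 3 cannot be read as steps of any size. The compounds shown leave open at what concentration, if any, compound 1, compound 2, compound 3 or compound 4 would harm these cells, and whether their different groups change that concentration at all.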